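The compounds below may be only part of what the source reports. "The series", "measured", "known", "first", "only" and "open" are said of these compounds alone.

Series notes. Compound 1 `CCOC(=O)c1sc(-c2cccc(NC(=O)c3cccc(F)c3)c2)nc1Nc1ccc(N2CCN(C)CC2)cc1` in a functional assay on Ramos cells (Homo sapiens) for antiproliferative activity, read by CCK-8 assay, with a stated time of 72 h (a higher number here means a weaker inhibitor, a lower number a stronger inhibitor), gives 12800 nM. Compound 2 `CN1CCN(c2ccc(Nc3nc(-c4cccc(NC(=O)c5ccccc5)c4)sc3C(=O)O)cc2)CC1` in this assay gives "not determined" (no result reported), no result being reported; compound 2 therefore stands nowhere on the numbers shown, and no step from it can be sized from measurement. Compound 3 `CN1CCN(c2ccc(Nc3nc(-c4cccc(NC(=O)c5cccc(F)c5)c4)sc3C(=O)O)cc2)CC1` differs from compound 2 by fluoro in place of hydrogen on an aromatic carbon. Among the compounds with values here, no measured pair covers this change, so the expected step in this assay is small, of no set direction, and not beyond the usual scatter. Compound 3 is expected to give about 15000 nM in this assay, estimated within 4000 nM to 50000 nM.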

Compound 3, half-maximal inhibitory concentration: 14000 nM
The estimate for compound 3 lay 1.1-fold (0.03 log units) above the measured number; measured number inside the range.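

In this assay, hydrogen in place of ethyl on the oxygen next to the carbonyl group gives a 1.1-fold higher number from compound 1 to compound 3 (0.04 log units; within the scatter) and so shows that, with the 3-fluorophenyl group held constant, the ethyl ester and the carboxylic acid cannot be told apart at this position. The step from hydrogen to fluoro on the aromatic carbon cannot be read, since compound 2 carries no number. No measurement bearing on this result is available.

Open, as far as these compounds go, is whether a primary amide or a longer chain on that carbonyl group would stay within the scatter. Also open, from the compounds shown here alone, is whether chloro or methoxy in place of the fluoro would move the number.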